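The source may report more compounds than this note shows. Statements on the series, on what has been measured and on what is new or still open speak of the compounds shown alone.

In a functional assay on MDA-MB-453 cells (Homo sapiens) for cytotoxicity, read by MTT assay, with a stated time of 72 h (on this read-out lower numbers stand for stronger inhibition and higher numbers for weaker inhibition), compound 1 (`CC(C)(C)C1=CC(=O)C=C(NCC(=O)O)C1=O`) gives 171000 nM, compound 3 (`CC(C)(C)C1=CC(=O)C=CC1=O`) gives 56800 nM, and compound 2 (`CSCC[C@H](NC1=CC(=O)C=C(C[C@]2(C)[C@@H](C)CC[C@]3(C)C(C)=CCC[C@@H]23)C1=O)C(=O)O`) gives 25600 nM, the lowest of the three numbers. Compound 4 (`CC1=CCC[C@H]2[C@](C)(CC3=CC(=O)C=C(NCC(=O)O)C3=O)[C@@H](C)CC[C@]12C`) is still unmeasured. The change from compound 2 is hydrogen in place of 2-(methylsulfanyl)ethyl on a saturated chain carbon bound to an amine nitrogen and a carbonyl carbon, which turns (1-carboxy-3-(methylsulfanyl)propyl)amino into (carboxymethyl)amino. Among the compounds with values here, no measured step makes this change. Within the data shown here, the only step available, a 3.0-fold lower number from compound 1 to compound 3 (0.48 log units; beyond the scatter), is modest and removes (carboxymethyl)amino entirely, so it bears only loosely. No step beyond the scatter is therefore expected in this assay, with at most a slight rise. The estimated step is a 1.3-fold higher number from compound 2 to compound 4 (0.10 log units; within the scatter). For compound 4 the estimate is 32000 nM, with an expected range of 13000 nM to 80000 nM.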

Compound 4, half-maximal inhibitory concentration: 5840 nM
The estimate for compound 4 lay 5.5-fold (0.74 log units) above the measured number; the whole stated range lies above it.
By their numbers in this assay, from the lowest: compound 4; then compound 2; then compound 3; then compound 1.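

Hydrogen in place of 2-(methylsulfanyl)ethyl on the saturated chain carbon bound to an amine nitrogen and a carbonyl carbon gives a 4.4-fold lower number from compound 2 to compound 4 (0.64 log units; beyond the scatter) in this assay and this is the first step read at this position. The position is therefore not silent to the change, and 2-(methylsulfanyl)ethyl is not needed for the lowest number in the series. Nothing available explains this step.

On these data alone, a methyl or a longer chain ending in an amine or a carboxylic acid at this carbon remains open. So does whether the step follows the size of the chain or the sulfur atom.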